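The compounds below may be only part of what the source reports. "The series", "measured", "known", "first", "only" and "open" are said of these compounds alone.

Measured in a functional assay on NCI-H460 cells (Homo sapiens) for cytotoxicity, read by MTT assay, with a stated time of 48 h; on this read-out lower numbers stand for stronger inhibition and higher numbers for weaker inhibition:
- Compound 1 `COc1ccc(/C=C/C(=O)/C=C/c2cc3ccccc3nc2Cl)c(OC)c1`: > 10000 nM
- Compound 2 `COc1ccc(/C=C/C(=O)/C=C/c2cc3ccccc3nc2Oc2ccc(Br)cc2)c(OC)c1`: > 10000 nM
- Compound 3 `COc1ccc(/C=C/C(=O)/C=C/c2cc3ccccc3nc2Oc2cccc(Cl)c2)c(OC)c1`: > 10000 nM

All three entries are limits, not numbers, so the series offers only (the limit of > 10000 nM in this assay, at which 3 of the 3 values shown sit). Compound 3 therefore has no exact standing, and its entry of > 10000 nM is a limit as well.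

The next compound, compound 4 `COc1cc(OC)c(/C=C/C(=O)/C=C/c2cc3ccccc3nc2Oc2cccc(Cl)c2)c(OC)c1`, has methoxy in place of hydrogen on an aromatic carbon. The same difference, read one bond further out, turns 2,4-dimethoxyphenyl into 2,4,6-trimethoxyphenyl.

Three measured steps are available, and all of them concern the other end of the molecule. They are a step that the two limits leave unreadable from compound 1 to compound 2, a step that the two limits leave unreadable from compound 1 to compound 3 and a step that the two limits leave unreadable from compound 2 to compound 3. None has a readable size, and none involves a methoxy group. For the measured compounds named here, they give no support for a step of any particular size or direction, so the expectation stays close to where compound 3 stands, with > 10000 nM as its only anchor. Compound 4 is thus expected to remain weak in this assay, quite possibly reported as a limit again.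

The expected step is a number no higher from compound 3 to compound 4 (the limit leaves the size open).

In this assay, the estimate for compound 4 is 10000 nM, with an expected range of 3000 nM to 30000 nM.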

Compound 4, half-maximal inhibitory concentration: > 10000 nM
Compound 4 ended at the assay's limit; the forecaster's own chance of this, stated with the estimate: 65%; the middle value lies on the limit itself.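

In this assay compound 4 gives > 10000 nM, a limit and not a number. Compound 3 also has only a limit, so no size can be read for the change from compound 3 to compound 4. The series now rests on a single entry: the limit of > 10000 nM in this assay, at which 4 of the 4 values shown sit.

The compounds shown leave open how strongly any of them acts in this assay, and whether the added methoxy changes that at all.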